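Compound 4 set against compound 2

The source may report more compounds than this note shows. Statements on the series, on what has been measured and on what is new or still open speak of the compounds shown alone.

Compound 2 (`CCOC(=O)c1c(-c2ccc(OC)cc2)oc2ccc(OCCCCCN3C(=O)/C(=N\O)c4ccccc43)cc12`) gives 64 ug/mL in an ADME assay on Vero cells (Chlorocebus sabaeus) for cytotoxicity, read by MTT assay, with a stated time of 72 h (on this read-out lower numbers stand for higher toxicity in this test and higher numbers for lower toxicity in this test), and stands far under compound 1 (`CCOC(=O)c1c(-c2ccc(OC)cc2)oc2ccc(OCCCCCN3C(=O)C(=O)c4cc(F)ccc43)cc12`) with 512 ug/mL and within the scatter of compound 3 (`CCO/N=C1\C(=O)N(CCCCOc2ccc3oc(-c4ccc(OC)cc4)c(C(=O)OCC)c3c2)c2ccc(F)cc21`) with 32 ug/mL as its value. Compound 4 (`CCOC(=O)c1c(-c2ccc(OC)cc2)oc2ccc(OCCCCCCN3C(=O)C(=O)c4ccccc43)cc12`) differs from compound 2 by a group of 12 heavy atoms (9 carbon, 1 nitrogen, 2 oxygen; one five-membered non-aromatic ring with 1 hetero atom, one six-membered aromatic ring of carbon only) in place of a group of 12 heavy atoms (8 carbon, 2 nitrogen, 2 oxygen; one five-membered non-aromatic ring with 1 hetero atom, one six-membered aromatic ring of carbon only), on a saturated chain carbon, five bonds along the chain from an oxygen on an aromatic ring as a change in one place. Among the measured compounds shown here, the one measured step that bears on it, an 8.0-fold lower number from compound 1 to compound 2 (0.90 log units; beyond the scatter) in size, ended in the group that leaves here, so the change runs roughly against that step, although the entering group is not that of compound 1. A smaller step, a 4.0-fold higher number from compound 2 to compound 4 (0.60 log units; beyond the scatter) as estimated, is expected towards a higher number in this assay for this series. Compound 4 is estimated at 256 ug/mL with an expected range of 64 ug/mL to 1024 ug/mL in this test.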

Compound 4, half-maximal cytotoxic concentration: 256 ug/mL
Beside the measured number, compound 4's estimate shows no gap at the digits printed, and the stated range covers the measured number.
By their numbers in this assay, from the lowest: compounds 3 and 2 (each within the scatter of the next); then compounds 4 and 1 (each within the scatter of the next).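

In this assay, the group of 12 heavy atoms with 9 carbon, 1 nitrogen and 2 oxygen reverses the earlier drop at this place without being the group of compound 1 (a 4.0-fold higher number from compound 2 to compound 4 (0.60 log units; beyond the scatter)). The other new step (a 2.0-fold lower number from compound 1 to compound 4 (0.30 log units; within the scatter)) does not separate these two groups, while the group with 1 hydrogen-bond donor and 3 hydrogen-bond acceptors stands apart from both. Nothing available explains the difference at this place. As far as these compounds go, whether an amine or a carboxylic acid on this chain would give a high or a low number remains open, as does the effect of a longer chain.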